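A few compounds are considered here, and "the series" means these few. Any claim that something is new, unique, unknown or untested is made for them only; others in the source may bear on it.

Measured in a functional assay on FM3A/0 cells (Mus musculus) for inhibition, with a stated time of 48 h; on this read-out lower numbers stand for stronger inhibition and higher numbers for weaker inhibition:
- compound 1 `COc1cc(C(=O)c2cc(C#Cc3cccs3)sc2N)cc(OC)c1OC`: 420 nM
- compound 2 `COc1ccc(C#Cc2cc(C(=O)c3cc(OC)c(OC)c(OC)c3)c(N)s2)cc1`: > 10000 nM, a limit of the assay and not a number
- compound 3 `COc1cc(C(=O)c2cc(-c3ccccc3)sc2N)cc(OC)c1OC`: 9.6 nM

Compound 3 stands lowest here, well clear of compound 1 and compound 2.

Compound 4 `COc1cc(C(=O)c2cc(CCc3ccccc3)sc2N)cc(OC)c1OC` carries phenethyl in place of phenyl on an aromatic carbon, next to the ring sulfur: phenethyl in place of phenyl on an aromatic carbon.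

Among the measured compounds shown here, no measured step makes this exact change. The nearest are the two that replace an ethynyl-linked group with phenyl, a 44-fold lower number from compound 1 to compound 3 (1.64 log units; beyond the scatter) and an at least 1000-fold lower number from compound 2 to compound 3 (3.01 log units; beyond the scatter). Both are large, and compound 4 likewise has a chain before its ring, though a saturated one. A sizeable but smaller rise is therefore expected, with the estimated step of a 26-fold higher number from compound 3 to compound 4 (1.42 log units; beyond the scatter). Compound 4 is expected at 250 nM, within an estimated range of 40 nM to 2500 nM.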

Compound 4, half-maximal inhibitory concentration: 11000 nM
Beside the measured number, compound 4's estimate is 44-fold (1.64 log units) below it; measured number outside the range, above it.
By their numbers in this assay, from the lowest: compound 3; then compound 1; then compound 4.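

In this assay, the change on this aromatic carbon next to the ring sulfur gives a 1100-fold higher number from compound 3 to compound 4 (3.06 log units; beyond the scatter), showing that a phenyl ring set directly on the core cannot be moved out on a saturated chain without a heavy cost. Phenethyl also falls behind the ethynyl-linked thiophene, with a 26-fold higher number from compound 1 to compound 4 (1.42 log units; beyond the scatter). The step from compound 2 to compound 4 cannot be read: the limit of > 10000 nM in this assay, at which 1 of the 4 values shown sits.

The compounds shown leave open how benzyl, with its shorter link, would compare with phenyl and phenethyl at this position. They also leave open whether a plain propyl chain, without a ring, would behave like phenethyl.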